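This account rests on a few compounds, and the source may have more. Where it says the series, first, only, none or still open, it means among the compounds named here.

Compound 1 `CN1C(=S)[C@@H](NC(=O)c2n[nH]c(Cc3ccccc3)n2)COc2ccccc21` and compound 2 `CN1C(=S)[C@@H](NC(=O)c2nc(Cc3ccccc3)n(CCCC#N)n2)COc2ccccc21` share a core and were both tested in a toxicity assay on HT-29 cells (Homo sapiens) for cytotoxicity; a higher number here means that more compound is tolerated, a lower number that less compound is tolerated. Compound 1 reaches only a limit of the assay, > 50000 nM. Compound 2 also reaches only a limit, > 100000 nM. The step that the two limits leave unreadable from compound 1 to compound 2 therefore cannot be read, as both values are limits. Compound 3 `CN1C(=S)[C@@H](NC(=O)c2nc(Cc3ccccc3)n(C3COC3)n2)COc2ccccc21` differs from compound 2 by oxetan-3-yl in place of 3-cyanopropyl on an aromatic nitrogen. Within the data shown here, no measured step bears on this change, so nothing beyond the scatter is expected. The estimate for compound 3 is 100000 nM, within a range from 30000 nM to 300000 nM. This expected outcome corresponds to a step of a number no higher from compound 2 to compound 3 (the limit leaves the size open).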

Compound 3, half-maximal cytotoxic concentration: > 100000 nM
Compound 3: only a limit was reported; the forecaster's own chance of this, stated with the estimate: 70%; the middle value sits exactly at the limit.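

Compound 3 also gives only a limit in this assay, so its steps from compound 1 and from compound 2 cannot be read. The compounds shown leave open at what concentration any of the three harms these cells.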